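Swapping a hydroxy for a fluoro on compound 1

The compounds below may be only part of what the source reports. "The series", "measured", "known", "first", "only" and "open" are said of these compounds alone.

Measured compounds:
compound 1 `COc1cc(OC)c(OC)cc1/C=C/C(=O)c1ccc(O)cc1` — 155000 nM
compound 2 `COc1cc(OC)c(OC)cc1/C=C/C(=O)c1ccc(Cl)c([N+](=O)[O-])c1` — 20600 nM
compound 3 `COc1cc(OC)c(-c2cc(=O)c3cc(Cl)ccc3o2)cc1OC` — a limit of the assay, > 150000 nM

Of the compounds shown here, three have been tested in a functional assay on SW982 cells (Homo sapiens) for inhibition, read by MTT assay, with a stated time of 72 h; on this read-out lower numbers stand for stronger inhibition and higher numbers for weaker inhibition. Compound 1 gives 155000 nM, the highest of the two numbers that are not limits. Compound 2 gives 20600 nM, a lower number by a margin that lies beyond the usual scatter. Compound 3 returns only a limit, > 150000 nM, and so is not a number to be ranked; it is the limit of > 150000 nM in this assay, at which 1 of the 3 values shown sits.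

Compound 4 `COc1cc(OC)c(OC)cc1/C=C/C(=O)c1ccc(F)cc1` has not yet been measured. It differs from compound 1 in one place: fluoro in place of hydroxy on an aromatic carbon. Among the measured compounds shown here, no pair of measured compounds covers this change, so the size of the step can only be estimated. For the measured compounds named here, since the only other numbered value, that of compound 2, is lower (20600 nM), the expectation leans toward a modest move to a lower number, or none beyond the scatter. Compound 4 is expected to give about 80000 nM, between 25000 nM and 200000 nM. The expected step is a 1.9-fold lower number from compound 1 to compound 4 (0.29 log units; within the scatter).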

Compound 4, half-maximal inhibitory concentration: 32500 nM
Beside the measured number, compound 4's estimate is 2.5-fold (0.39 log units) above it; the measured number falls inside the stated range.
By their numbers in this assay, from the lowest: compounds 2 and 4 (each within the scatter of the next); then compound 1.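

In this assay, fluoro in place of hydroxy on the aromatic carbon para to a large group gives a 4.8-fold lower number from compound 1 to compound 4 (0.68 log units; beyond the scatter), the first step read at this position. The 4-hydroxyphenyl group of compound 1 is therefore not required for a measurable value on this core, and the 4-fluorophenyl group, which has no hydrogen-bond donor or acceptor in the count, goes with the lower number. Nothing among the measurements shown accounts for why the number moves.

As far as these compounds go, whether an amine, a carboxylic acid or a longer chain at this same place would move the number further, or back up, remains open. Among the compounds shown here, compound 3 gives > 150000 nM, which is a limit of the assay and not a number, and no step to it can be read.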